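The compounds below may be only part of what the source reports. "The series", "measured", "known", "first", "only" and "open" are said of these compounds alone.

Series notes, cytotoxicity.

- Compound 1, `Cc1cc(=O)n(-c2ccccc2OC(F)(F)F)nc1C(=O)Nc1ccc(Oc2ncnc3c2ccn3C)c(F)c1`: in a functional assay on HepG2 cells (Homo sapiens) for cytotoxicity, read by MTT assay, with a stated time of 72 h (a higher number here means a weaker inhibitor, a lower number a stronger inhibitor), compound 1 reaches only the assay limit, > 60000 nM.
- Compound 2, `Cc1ccc(-n2nc(C(=O)Nc3ccc(Oc4ncnc5c4ccn5C)c(F)c3)c(C)cc2=O)cc1`: in this assay compound 2 likewise gives only a limit, > 60000 nM.

Compound 2 therefore stands at the limit, and the other measured value is a limit as well, so no ordering within the pair can be read. Within the data shown here, the one measured step, a step that the two limits leave unreadable from compound 1 to compound 2, cannot be sized from two limits. Compound 3, `Cc1cc(=O)n(-c2ccccc2Cl)nc1C(=O)Nc1ccc(Oc2ncnc3c2ccn3C)c(F)c1`, is not yet measured; it differs from compound 2 in that (2-chlorophenyl in place of 4-methylphenyl on an aromatic nitrogen). Among the measured compounds shown here, no measured step covers this change; what the numbers offer is only (the limit of > 60000 nM in this assay, at which 2 of the 2 values shown sit), where both known values sit. The expectation for compound 3 in this assay is thus a further limit or a value close to it, with no direction beyond the scatter. Compound 3 is estimated at 80000 nM, within 20000 nM to 300000 nM. The step from compound 2 to compound 3 is expected as a step that the limit leaves unreadable from compound 2 to compound 3.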

Compound 3, half-maximal inhibitory concentration: > 60000 nM
Compound 3: only a limit was reported (the forecaster's own chance of this, stated with the estimate: 80%); the middle value is on the limit's open side.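

Compound 3 gives only a limit in this assay, > 60000 nM, so the steps among compound 1, compound 2 and compound 3 cannot be read. The compounds shown leave open whether the groups on the aromatic nitrogen differ at all in cytotoxicity.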